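Swapping a sulfonyl group for hydrogen on compound 2

The source may hold more compounds than are shown below. What is called first, only, known or untested is meant among the compounds shown, and "the series" means these compounds.

- compound 1 `O=c1[nH]/c(=C\c2cccc(Oc3ccc(F)cc3)c2)c(=O)[nH]/c1=C\c1cccnc1` reads > 1000 nM as a limit
- compound 2 `CC(C)(C)S(=O)(=O)OCc1ccc(/C=c2\[nH]c(=O)/c(=C/c3cccc(Oc4ccc(F)cc4)c3)[nH]c2=O)o1` reads 378 nM as a number

Going by the values given here, in a functional assay on NCI-H460 cells (Homo sapiens) for cytotoxicity, read by MTT assay, with a stated time of 72 h (on this read-out lower numbers stand for stronger inhibition and higher numbers for weaker inhibition), compound 2 stands at 378 nM and holds the only exact number so far. The reading of compound 1 is a limit. Compound 3 `O=c1[nH]/c(=C\c2ccc(CO)o2)c(=O)[nH]/c1=C\c1cccc(Oc2ccc(F)cc2)c1` is not yet measured. Its structure departs from compound 2 by hydrogen in place of (tert-butyl)sulfonyl on an oxygen on a saturated carbon and so carries hydroxymethyl in place of (((tert-butyl)sulfonyl)oxy)methyl. Among the compounds with values here, no measured pair shows what this change does. The expected size of the step of a 1.1-fold lower number from compound 2 to compound 3 (0.03 log units; within the scatter) in this assay is nothing beyond the usual scatter, with no firm direction. For compound 3 the estimate is 350 nM with an expected range from 90 nM to 1300 nM.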

Compound 3, half-maximal inhibitory concentration: 41.5 nM
Beside the measured number, compound 3's estimate is 8.4-fold (0.93 log units) above it; measured number outside the range, below it.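

In this assay, this first measured pair at the oxygen shows that hydroxymethyl reads stronger than (((tert-butyl)sulfonyl)oxy)methyl, with a 9.1-fold lower number from compound 2 to compound 3 (0.96 log units; beyond the scatter) as the step. Placing 5-(hydroxymethyl)furan-2-yl where compound 1 carries pyridin-3-yl gives an at least 24-fold lower number from compound 1 to compound 3 (1.38 log units; beyond the scatter) as its step. Compound 1 reads as a limit, not a number: the limit of > 1000 nM in this assay, at which 1 of the 3 values shown sits.

As far as these compounds go, whether an amine or a methoxy group in place of the hydroxy would hold this reading stays open. Also open is whether the hydroxymethyl group is needed at all on the furan, as an unsubstituted furan-2-yl is not among the compounds shown.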